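A second ethoxycarbonyl swap on the shared core

The compounds below may be only part of what the source reports. "The series", "measured", "known", "first", "only" and "open" are said of these compounds alone.

Measured in a functional assay on B16 cells (Mus musculus) for cytotoxicity, read by MTT assay, with a stated time of 48 h; on this read-out lower numbers stand for stronger inhibition and higher numbers for weaker inhibition
Compound 1 `O=C(Nc1cccc(-c2cn(Cc3ccccc3)nn2)c1)c1cn(Cc2ccccc2)nn1` gives 4500 nM
Compound 2 `CCOC(=O)Cn1cc(-c2cccc(NC(=O)c3cn(Cc4ccccc4)nn3)c2)nn1` gives 21000 nM
Compound 3 `CCOC(=O)Cn1cc(C(=O)Nc2cccc(-c3cn(Cc4ccccc4)nn3)c2)nn1` gives 20400 nM

Compound 3 (20400 nM) sits within the usual scatter of compound 2 (21000 nM) in this assay and so counts as level with it. Compound 1 (4500 nM) shows the lowest number of the three, clearly apart from both.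

Compound 4 `CCOC(=O)Cn1cc(C(=O)Nc2cccc(-c3cn(CC(=O)OCC)nn3)c2)nn1` is the next structure to consider. Its difference from compound 3 is ethoxycarbonyl in place of phenyl on a saturated chain carbon bound to an aromatic nitrogen. In words, this is ethoxycarbonyl in place of phenyl on a saturated chain carbon bound to an aromatic nitrogen, so the remaining benzyl becomes (ethoxycarbonyl)methyl.

Two measured steps made this same swap, and both weakened inhibition: a 4.7-fold higher number from compound 1 to compound 2 (0.67 log units; beyond the scatter) and a 4.5-fold higher number from compound 1 to compound 3 (0.66 log units; beyond the scatter). Among the measured compounds shown here, both steps started from compound 1, so no measurement yet shows what a second swap does on a compound that has already had one. A step in the same upward direction and of similar size is therefore expected, with real uncertainty.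

The expected change is a 3.4-fold higher number from compound 3 to compound 4 (0.54 log units; beyond the scatter).

Compound 4 is estimated at 70000 nM in this assay with an expected range from 25000 nM to 200000 nM as its limits of confidence.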

Compound 4, half-maximal inhibitory concentration: > 100000 nM
Compound 4 ended at the assay's limit (the forecaster's own chance of this, stated with the estimate: 25%); at least 1.4-fold (0.15 log units) between middle value and limit.
By their numbers in this assay, from the lowest: compound 1; then compounds 3 and 2 (each within the scatter of the next). At a limit, above all of these: compound 4.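

The swap still raises the number when it is made a second time, on a compound that has already lost one benzyl: in this assay the steps are an at least 4.9-fold higher number from compound 3 to compound 4 (0.69 log units; beyond the scatter) and an at least 4.7-fold higher number from compound 2 to compound 4 (0.67 log units; beyond the scatter). Compound 4 reads > 100000 nM, which is a limit of the assay and not a number. The second swap is therefore at least comparable in size with the first, and the two can be set side by side only this far: the same change on two cores in this assay, a 4.7-fold higher number (0.67 log units; beyond the scatter) from compound 1 to compound 2 and an at least 4.9-fold higher number (0.69 log units; beyond the scatter) from compound 3 to compound 4; the limit leaves it open whether they differ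

Going by these compounds, how much weaker compound 4 really is stays open, and so does whether the second swap costs more than the first. On these data alone, it is also open whether a carboxylic acid or an amine in place of ethoxycarbonyl, on a saturated chain carbon bound to an aromatic nitrogen, would bring the number back towards that of compound 1 at 4500 nM.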